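Compound 1 and its methyl amide, compound 4

The source may report more compounds than this note shows. Statements on the series, on what has been measured and on what is new or still open speak of the compounds shown alone.

In a functional assay on A-375 cells (Homo sapiens) for inhibition, read by MTT assay, with a stated time of 120 h (on this read-out lower numbers stand for stronger inhibition and higher numbers for weaker inhibition), compound 1 `C/C(=C\c1ccc(NC(=O)Nc2ccc(Cl)c(C(F)(F)F)c2)cc1)C(=O)NC(C)c1ccccc1` reads > 50000 nM, which is a limit of the assay and not a number. On the numbers available, compound 1 stands at the limit of > 50000 nM in this assay, at which 1 of the 3 values shown sits.

Two further compounds give measured numbers. Compound 2 `CC(NC(=O)C#Cc1ccc(NC(=O)Nc2cc(C(F)(F)F)ccc2Cl)cc1)c1ccccc1` reads 30500 nM. Compound 3 `CC(NC(=O)c1cccc(-c2ccc(NC(=O)Nc3ccc(Cl)c(C(F)(F)F)c3)cc2)c1)c1ccccc1` reads 5170 nM, the lower of these two numbers. Both carry the same 1-phenylethyl amide as compound 1, but neither forms a single-place step with it, so the size of any change in this series remains unmeasured.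

The next compound to be read is compound 4 `CNC(=O)/C(C)=C/c1ccc(NC(=O)Nc2ccc(Cl)c(C(F)(F)F)c2)cc1`. It keeps the core of compound 1 and has methyl in place of 1-phenylethyl on an amide-type nitrogen. Among the compounds with values here, no measured pair shows this exchange, so the expectation has no direct support and the direction is uncertain. Only a small change in this assay is expected, and it may stay within the usual scatter. The estimated move is an at least 1.1-fold lower number from compound 1 to compound 4 (0.04 log units; that floor lies within the scatter), and it starts from a limit rather than a number. A further reading at the limit is also expected to be quite possible.

For compound 4 the estimated value is 45000 nM, with an expected range of 15000 nM to 100000 nM.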

Compound 4, half-maximal inhibitory concentration: > 50000 nM
Compound 4 gave a limit, no number (the forecaster's own chance of this, stated with the estimate: 50%); at least 1.1-fold (0.04 log units) between middle value and limit.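

Compound 1 and compound 4 both give a limit rather than a number in this assay, so no step can be read between them: the limit of > 50000 nM in this assay, at which 2 of the 4 values shown sit.

The compounds shown leave open the size, and even the direction, of any effect of methyl in place of 1-phenylethyl on the amide-type nitrogen.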